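The source may hold more compounds than are shown below. What is called first, only, known or untested is meant among the compounds shown, and "the series" means these compounds.

Compound 1 `COc1ccc(N(C)c2nc(C)nc3ccccc23)cc1C(=O)OCCC[Se]C#N`: 1140 nM
Compound 2 `C[Se]c1ccc(N(C)c2nc(C)nc3ccccc23)cc1C`: 8 nM

The measure throughout is a functional assay on RKO cells (Homo sapiens) for inhibition, read by MTT assay, with a stated time of 48 h; a lower number here means a stronger inhibitor, a higher number a weaker inhibitor. Of the two measured compounds, compound 1 has the higher number: in this assay compound 1 gives 1140 nM, whereas compound 2 gives 8 nM, a gap well beyond the scatter. Compound 3 `COc1ccc(N(C)c2nc(C)nc3ccccc23)cc1OCCCCC[Se]C#N` has not been measured. It differs from compound 1 in one place: a group of 9 heavy atoms (6 carbon, 1 nitrogen, 1 oxygen, 1 selenium; no ring) in place of a group of 9 heavy atoms (5 carbon, 1 nitrogen, 2 oxygen, 1 selenium; no ring), on an aromatic carbon The group that leaves carries a double bond and a triple bond outside aromatic rings; the group that enters carries only a triple bond, and the site is ortho to a methoxy group and meta to a large group. Among the compounds with values here, no measured pair shows the effect of such a change, and compound 2 differs from compound 1 in more than this one place, so its value is no guide. The expected step is a 1.3-fold lower number from compound 1 to compound 3 (0.10 log units; within the scatter), small and without a clear direction beyond the scatter. Compound 3 is therefore expected to come out near 900 nM, within a range from 300 nM to 3000 nM.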

Compound 3, half-maximal inhibitory concentration: 3560 nM
Estimate against measurement, compound 3: 4.0-fold (0.60 log units) below; measured number outside the range, above it.
By their numbers in this assay, from the lowest: compound 2; then compound 1; then compound 3.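

In this assay, putting the group that carries only a triple bond in place of the one that carries a double bond and a triple bond, on the aromatic carbon ortho to a methoxy group, gives a 3.1-fold higher number from compound 1 to compound 3 (0.49 log units; beyond the scatter). Within the data shown here, as the only single-place step available, it shows that this site responds to the make-up of the group, since two groups with the same heavy-atom count, neither with a ring, are separated beyond the usual scatter. Nothing given here explains this step.

The step cannot be split between the loss of the double bond and the other differences between the two groups, as both change together. From the compounds shown here alone, how a longer chain, a shorter chain, an amine or a carboxylic acid at this site would compare also remains open.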